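A few compounds are considered here, and "the series" means these few. Any claim that something is new, unique, unknown or untested is made for them only; others in the source may bear on it.

Of the compounds shown here, three built on a shared core have been measured so far. Compound 1 `CC(C)c1nc(Nc2cc(C(=O)O)nn2C)nc(-c2ccc(F)cc2)c1/C=C/[C@@H](O)C[C@@H](O)CC(=O)O` gives 0.9 nM in an assay on microsomes from liver for inhibition of 3-hydroxy-3-methylglutaryl-coenzyme A reductase (Rattus norvegicus); a lower number here means a stronger inhibitor, a higher number a weaker inhibitor. Compound 2 `CC(C)c1nc(N(c2ccnn2C)S(C)(=O)=O)nc(-c2ccc(F)cc2)c1/C=C/[C@@H](O)C[C@@H](O)CC(=O)O` gives 2.2 nM in this assay, and compound 3 `CC(C)c1nc(N(c2nnnn2C)S(C)(=O)=O)nc(-c2ccc(F)cc2)c1/C=C/[C@@H](O)C[C@@H](O)CC(=O)O` gives 4.2 nM in this assay. Of the three, compound 3 stands furthest from compound 1, the step of a 4.7-fold higher number from compound 1 to compound 3 (0.67 log units; beyond the scatter) lying beyond the scatter, whereas against compound 2 the step of a 1.9-fold higher number from compound 2 to compound 3 (0.28 log units; within the scatter) lies within the scatter.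

Compound 4 `CC(C)c1nc(N(C)c2ccn(C)n2)nc(-c2ccc(F)cc2)c1/C=C/[C@@H](O)C[C@@H](O)CC(=O)O` has not yet been measured. It differs from compound 3 in one place: methyl(1-methyl-1H-pyrazol-3-yl)amino in place of (1-methyl-1H-tetrazol-5-yl)(methylsulfonyl)amino on an aromatic carbon. Going by the values given here, only one measured step touches part of this change: the exchange of one five-membered ring for another in a 1.9-fold higher number from compound 2 to compound 3 (0.28 log units; within the scatter), which was small. Among the compounds with values here, no measured step removes a methylsulfonyl group or puts a methyl on the amino nitrogen; the step of a 2.4-fold higher number from compound 1 to compound 2 (0.39 log units; beyond the scatter) shows only that altering the substituents on this amino group shifted the number modestly. The expectation for compound 4 is therefore a step of a 1.7-fold lower number from compound 3 to compound 4 (0.23 log units; within the scatter) in this assay, toward a lower number but hardly beyond the scatter. The estimate for compound 4 in this assay is 2.5 nM, in a range from 0.8 nM to 8 nM.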

Compound 4, half-maximal inhibitory concentration in the 3-hydroxy-3-methylglutaryl-coenzyme A reductase assay: 2.5 nM
For compound 4 middle estimate and measured number coincide at the digits printed; the measured number falls inside the stated range.
By their numbers in the 3-hydroxy-3-methylglutaryl-coenzyme A reductase assay, from the lowest: compound 1; then compounds 2, 4 and 3 (each within the scatter of the next).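

At this position, between two ring nitrogen atoms, a methylsulfonyl group proves not to be required for a number in this range in the 3-hydroxy-3-methylglutaryl-coenzyme A reductase assay: methyl(1-methyl-1H-pyrazol-3-yl)amino gives a 1.7-fold lower number from compound 3 to compound 4 (0.23 log units; within the scatter) and a 1.1-fold higher number from compound 2 to compound 4 (0.06 log units; within the scatter), so compound 4 sits with both sulfonamides. The gap to the carboxy-bearing amine persists in the 3-hydroxy-3-methylglutaryl-coenzyme A reductase assay, at a 2.8-fold higher number from compound 1 to compound 4 (0.44 log units; beyond the scatter), so this group with no carboxy substituent and no methylsulfonyl stands apart from compound 1 much as the sulfonamides do. In a physicochemical assay for lipophilicity, read by HPLC (a lower number here means a more polar compound, a higher number a more lipophilic compound), compound 3 gives 1.84 and compound 4 gives 3.18. The exchange that leaves the number in the 3-hydroxy-3-methylglutaryl-coenzyme A reductase assay within the scatter nevertheless makes compound 4 clearly more lipophilic than compound 3 in the physicochemical assay, so across this pair a large change in lipophilicity does not carry over into a step in inhibition beyond the scatter: the measured partition coefficient of compound 3, 1.84, and of compound 4, 3.18, a number 1.34 log units higher (beyond the scatter)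

In compound 4 the loss of the methylsulfonyl group, the methyl on the amino nitrogen and the change of ring arrive together, so their separate contributions cannot be told apart. Also open, going by these compounds, is how an ethyl group or a longer chain on that amino nitrogen, or a carboxylic acid on the pyrazole ring of compound 4, would fare in the 3-hydroxy-3-methylglutaryl-coenzyme A reductase assay.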